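Swapping a benzamide for an imidazole on the sulfur-linked arm

This account rests on a few compounds, and the source may have more. Where it says the series, first, only, none or still open, it means among the compounds named here.

Of the compounds shown here, three sharing one core have been measured in a functional assay on CHO cells for agonist activity at adenosine receptor A2b (Homo sapiens), read by AlphaScreen and cAMP accumulation; a lower number here means that less compound is needed, a higher number that more compound is needed for the effect. Compound 1 `CCOc1ccc(-c2c(C#N)c(N)nc(SCc3ccn[nH]3)c2C#N)cc1` gives 332 nM; compound 3 `CCOc1ccc(-c2c(C#N)c(N)nc(SCC(N)=O)c2C#N)cc1` gives 38 nM; compound 2 `N#Cc1c(N)nc(SCc2cccc(C(N)=O)c2)c(C#N)c1-c1ccc(OCC2CC2)cc1` gives 12.7 nM, the lowest of the three numbers, beyond the scatter from both others. For the measured compounds named here, the one single-point step among them, an 8.7-fold lower number from compound 1 to compound 3 (0.94 log units; beyond the scatter), shows that trading a small azole for a carbamoyl group on the chain carbon bound to sulfur lowered the number. Compound 4 `N#Cc1c(N)nc(SCc2cnc[nH]2)c(C#N)c1-c1ccc(OCC2CC2)cc1` is the unmeasured neighbour of compound 2, and the change is 1H-imidazol-5-yl in place of 3-carbamoylphenyl on a saturated chain carbon bound to a sulfur. This is close to the reverse of the step from compound 1 to compound 3: an amide-bearing group leaves and a small five-membered azole enters. A rise in the number of a modest size is therefore expected, though imidazole rather than pyrazole and the different alkoxy group leave room for doubt. Compound 4 is estimated at 80 nM, expected between 20 nM and 320 nM, a step of a 6.3-fold higher number from compound 2 to compound 4 (0.80 log units; beyond the scatter).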

Compound 4, half-maximal effective concentration: 139 nM
Beside the measured number, compound 4's estimate is 1.7-fold (0.24 log units) below it; low and high end bracket the measured number.
By their numbers in this assay, from the lowest: compound 2; then compound 3; then compound 4; then compound 1.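

In this assay, replacing the larger arm with the imidazole gives an 11-fold higher number from compound 2 to compound 4 (1.04 log units; beyond the scatter), so this position on the sulfur-linked chain responds strongly on a second version of the core, one with a different alkoxy group. Across the two single-change pairs, the compound with the amide-bearing arm has the lower number, whether the amide sits directly on the chain, as in compound 3, or on a phenyl ring, as in compound 2. The 3-carbamoylphenyl and 1H-imidazol-5-yl groups carry the same counts of hydrogen-bond donors and acceptors, and nothing available explains the shift.

As far as these compounds go, it remains open whether the amide or the phenyl ring matters more: a plain benzyl group would separate the two, and a 3-carboxybenzyl group would test the amide itself. The effect of the alkoxy group alone also remains unresolved.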